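This account rests on a few compounds, and the source may have more. Where it says the series, first, only, none or still open, it means among the compounds named here.

Working notes on the series. In a functional assay on the whole organism (artery, strain albino) with Rattus norvegicus as the target, with a stated time of 60 min, at a dose of 10 mg/kg by the oral route (a higher number here means more inhibition at the dose given (going by the name of the read-out), a lower number less inhibition), compound 1 `CC1=C(C(=O)Nc2ccc([N+](=O)[O-])cc2)C(c2ccc(Br)cc2)N=C(SCc2ccc(F)cc2)N1` gives 9.7%. In this assay compound 2 `CC1=C(C(=O)Nc2ccc([N+](=O)[O-])cc2)C(c2cccc([N+](=O)[O-])c2)N=C(SCc2ccccc2)N1` gives 7.7%. In this assay compound 3 `CC1=C(C(=O)Nc2ccc([N+](=O)[O-])cc2)C(c2cccc([N+](=O)[O-])c2)N=C(SCc2ccc(Cl)cc2)N1` gives 6.7%. Within the data shown here, the one single-point step among the measured compounds, a number 1 percentage points lower from compound 2 to compound 3 (within the scatter), is within the scatter. Taken purely as numbers, the figure of compound 3 is the lowest of the three, but compound 2 and compound 1 both lie within the scatter of it, so no order among the three is claimed.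

Compound 4 `CC1=C(C(=O)Nc2ccc([N+](=O)[O-])cc2)C(c2cccc([N+](=O)[O-])c2)N=C(SCc2ccc(F)cc2)N1` differs from compound 3 by fluoro in place of chloro on an aromatic carbon. Among the measured compounds shown here, no measured pair changes fluoro against chloro directly. The step from compound 2 to compound 3 bears on the same benzyl ring and stayed within the scatter. Compound 1 carries the 4-fluorobenzyl found in compound 4, but it also differs at another aryl, so only its value can be noted; that value sits within the scatter of compound 3. On this basis no step beyond the scatter is expected, and the estimated step is a number 1.3 percentage points higher from compound 3 to compound 4 (within the scatter). For compound 4 in this assay the estimate is 8%, with a range from 2% to 15%.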

Compound 4, a percentage reported as inhibition, in the whole organism at one dose (the size of the read-out at that dose, not a potency): 7.2%
Compound 4: middle estimate off by 0.8 percentage points, on the high side; the measured number falls inside the stated range.
By their numbers in this assay, from the lowest: compounds 3, 4, 2 and 1 (each within the scatter of the next).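

In this assay, the direct exchange on the benzyl ring, on the aromatic carbon para to a large group, reads (a number 0.5 percentage points higher from compound 3 to compound 4 (within the scatter)), and fluoro in place of hydrogen on that carbon reads (a number 0.5 percentage points lower from compound 2 to compound 4 (within the scatter)). Together with the earlier step (a number 1 percentage points lower from compound 2 to compound 3 (within the scatter)), this places hydrogen, fluoro and chloro at this position within the scatter of one another, so the series gives no order among the three. Among these compounds, the new compound also provides the first single-place reading at the aryl on the saturated ring carbon, with the 4-fluorobenzyl held in common: 3-nitrophenyl in place of 4-bromophenyl reads (a number 2.5 percentage points lower from compound 1 to compound 4 (within the scatter)), so no step read so far, at either place, leaves the scatter.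

Still open, on these data alone, is whether an amine, a carboxylic acid or a methoxy group at this place on the benzyl ring, or a longer chain in place of the benzyl on the sulfur, would give a step beyond the scatter at this single dose. Nothing at hand bears on what lies behind these numbers.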